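The compounds below may be only part of what the source reports. "The series", "measured", "known", "first", "only" and "open" are said of these compounds alone.

In a functional assay on MGC-803 cells (Homo sapiens) for cytotoxicity, read by MTT assay, with a stated time of 72 h (a lower number here means a stronger inhibitor, a higher number a weaker inhibitor), compound 1 `O=C1C(=Cc2ccc(O)cc2)C(=O)N(c2ccc(Cl)cc2)N1c1ccc(Cl)cc1` gives 19500 nM, compound 2 `O=C1C(=Cc2ccc(Cl)cc2)C(=O)N(c2ccc(Cl)cc2)N1c1ccc(Cl)cc1` gives 32600 nM and compound 3 `COc1cccc(C=C2C(=O)N(c3ccc(Cl)cc3)N(c3ccc(Cl)cc3)C2=O)c1` gives 26600 nM. Compound 3 therefore stands within the scatter of both others, as a 1.4-fold higher number from compound 1 to compound 3 (0.13 log units; within the scatter) and a 1.2-fold lower number from compound 2 to compound 3 (0.09 log units; within the scatter) show. Compound 4 `O=C1C(=C/C=C/c2ccccc2)C(=O)N(c2ccc(Cl)cc2)N1c1ccc(Cl)cc1` differs from compound 3 in one place: 2-phenylethenyl in place of 3-methoxyphenyl on a double-bonded chain carbon bound to a double-bonded ring carbon. It carries 2-phenylethenyl in place of 3-methoxyphenyl on a double-bonded chain carbon bound to a double-bonded ring carbon. Those two steps changed the group at this same place, while a 1.7-fold higher number from compound 1 to compound 2 (0.22 log units; within the scatter) is also small, but none of them introduces 2-phenylethenyl. No step beyond the scatter is therefore expected in this assay. The expected change is a 1.2-fold lower number from compound 3 to compound 4 (0.08 log units; within the scatter). Compound 4 is estimated at 22000 nM, within an expected range of 9000 nM to 45000 nM.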

Compound 4, half-maximal inhibitory concentration: 5100 nM
Estimate against measurement, compound 4: 4.3-fold (0.63 log units) above, outside the stated range (below it).
By their numbers in this assay, from the lowest: compound 4; then compounds 1, 3 and 2 (each within the scatter of the next).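

In this assay this place had shown no step beyond the scatter, yet 2-phenylethenyl brings a 5.2-fold lower number from compound 3 to compound 4 (0.72 log units; beyond the scatter) and a 6.4-fold lower number from compound 2 to compound 4 (0.81 log units; beyond the scatter) and also a 3.8-fold lower number from compound 1 to compound 4 (0.58 log units; beyond the scatter) so the place on the double-bonded chain carbon does respond to a change of group. The heavy-atom count is the same in 3-methoxyphenyl and 2-phenylethenyl, so the step comes without a change in that count. No measurement shown here accounts for the step.

Still open, as far as these compounds go, is whether the chain's double bond matters, which a 2-phenylethyl group would test. From the compounds shown here alone, a hydroxy or chloro on the phenyl of 2-phenylethenyl also remains unexplored here.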